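A few compounds are considered here, and "the series" means these few. Any claim that something is new, unique, unknown or untested is made for them only; others in the source may bear on it.

Compound 1 `CCN(CC)C(=O)c1ccsc1NC(=O)c1cccs1`: < 30000 nM, a limit
Compound 2 `CCN(CC)C(=O)c1c(NC(=O)c2ccsc2)sc2c1CCCC2`: 29400 nM
Compound 3 `CCN(CC)C(=O)c1c(NC(=O)c2ccco2)sc2c1CCCC2`: > 30000 nM, a limit

These results come from a functional assay on A549 cells (Homo sapiens) for cytotoxicity, with a stated time of 60 h; a higher number here means that more compound is needed for the effect, a lower number that less compound is needed. Compound 3 has no exact number, only the limit > 30000 nM.

Compound 4 `CCN(CC)C(=O)c1c(NCc2cccs2)sc2c1CCCC2` differs from compound 3 in one place: (thiophen-2-yl)methyl in place of (furan-2-yl)carbonyl on a nitrogen on an aromatic ring. The new group, (thiophen-2-yl)methyl, takes the place of (furan-2-yl)carbonyl on a nitrogen on an aromatic ring.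

Among the measured compounds shown here, the only measured step is an at least 1.0-fold higher number from compound 2 to compound 3 (0.00 log units; that floor lies within the scatter). It keeps the carbonyl, so it is a weak guide here. For the measured compounds named here, compound 2, at 29400 nM, has the only exact value, and no change beyond the scatter is expected in this assay.

The expected outcome is an at least 1.2-fold lower number from compound 3 to compound 4 (0.07 log units; that floor lies within the scatter). Compound 4 is estimated at 25000 nM, with an expected range of 9000 nM to 30000 nM.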

Compound 4, half-maximal effective concentration: > 30000 nM
Compound 4 was reported as a limit; the forecaster's own chance of this, stated with the estimate: 50%; middle value at least 1.2-fold (0.07 log units) from the limit.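

In this assay compound 4 is reported only as a limit, > 30000 nM. Among the compounds shown here, the step from compound 3 cannot be read, and the one readable step is an at least 1.0-fold higher number from compound 2 to compound 4 (0.00 log units; that floor lies within the scatter). Compound 4, the only compound shown without a carbonyl on this nitrogen, therefore gives no sign of a lower number, and the values remain at the edge of the assay's range: the limit of > 30000 nM in this assay, at which 2 of the 4 values shown sit.

As far as these compounds go, whether any group on this nitrogen can give a number clearly lower than these remains open. A longer chain or an amine in place of (thiophen-2-yl)methyl would test that.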